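The source may hold more compounds than are shown below. What is called first, only, known or untested is meant among the compounds shown, and "the series" means these compounds.

Compound 1 `CC(C)(C)Nc1n[n+]([O-])c2ccccc2[n+]1[O-]`: 8 ug/mL
Compound 2 `[O-][n+]1nc(NC2CCCCC2)[n+]([O-])c2ccccc21`: 8.9 ug/mL

Both values come from an ADME assay on Vero cells (Chlorocebus sabaeus) for cytotoxicity, read by CellTiter-Glo, with a stated time of 72 h; on this read-out lower numbers stand for higher toxicity in this test and higher numbers for lower toxicity in this test. Compound 1 gives 8 ug/mL, the lower number of the pair, but compound 2 at 8.9 ug/mL lies within the scatter of it. Compound 3 `[O-][n+]1nc(N2CCCC2)[n+]([O-])c2ccccc21` has not yet been measured in this assay. Its change from compound 1 is pyrrolidin-1-yl in place of (tert-butyl)amino on an aromatic carbon. Going by the values given here, only one measured step bears on this, and only in part: a 1.1-fold higher number from compound 1 to compound 2 (0.05 log units; within the scatter), with cyclohexyl in place of tert-butyl on a nitrogen on an aromatic ring. Among the compounds with values here, no measured compound carries pyrrolidin-1-yl, so the range stays wide. On that small step, no shift beyond the scatter is expected in this assay, and the estimated step is a 1.1-fold higher number from compound 1 to compound 3 (0.05 log units; within the scatter). For compound 3 the expected value is 9 ug/mL, with an estimated range of 3.5 ug/mL to 25 ug/mL.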

Compound 3, half-maximal cytotoxic concentration: 17 ug/mL
Estimate against measurement, compound 3: 1.9-fold (0.28 log units) below; the measured number falls inside the stated range.
By their numbers in this assay, from the lowest: compounds 1, 2 and 3 (each within the scatter of the next, the first and the last beyond it).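

In this assay, pyrrolidin-1-yl in place of (tert-butyl)amino on the aromatic carbon between two ring nitrogen atoms is a change that moves the number beyond the scatter (a 2.1-fold higher number from compound 1 to compound 3 (0.33 log units; beyond the scatter)), a modest shift towards lower toxicity in this test. The earlier change of the group on the nitrogen, cyclohexyl for tert-butyl, stayed within the scatter (a 1.1-fold higher number from compound 1 to compound 2 (0.05 log units; within the scatter)), whereas this one swaps in a ring closed on that nitrogen, with the hydrogen-bond donor gone and the heavy-atom count unchanged. Nothing available explains the shift.

The compounds shown leave open whether the ring or the missing donor goes with the higher number, a question that an open-chain diethylamino group at this position would bear on. They also leave open how a larger ring such as piperidin-1-yl or morpholin-4-yl would read here.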